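Cytotoxicity notes: 3-chlorophenyl versus 4-chlorophenyl analogues

The compounds below may be only part of what the source reports. "The series", "measured", "known", "first", "only" and "open" are said of these compounds alone.

Measured so far in a functional assay on HT-1080 cells (Homo sapiens) for cytotoxicity, read by MTT assay, with a stated time of 72 h; on this read-out lower numbers stand for stronger inhibition and higher numbers for weaker inhibition:
- compound 1, `COc1cccc(/C=C2\CCC/C(=C\c3cccc(Cl)c3)C2=O)c1OC`, gives 10300 nM
- compound 2, `COc1cccc(/C=C2\CCC/C(=C\c3ccc(Cl)cc3)C2=O)c1OC`, gives 11100 nM
- compound 3, `COc1ccc(/C=C2\CCC/C(=C\c3cccc(Cl)c3)C2=O)cc1OC`, gives 4900 nM

Among the measured compounds shown here, the one step between measured compounds that differ in a single place is 4-chlorophenyl in place of 3-chlorophenyl on a double-bonded chain carbon bound to a double-bonded ring carbon. In this assay it gave a 1.1-fold higher number from compound 1 to compound 2 (0.03 log units; within the scatter), so the two chlorophenyl isomers on the core of compound 1 cannot be told apart on this read-out.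

Compound 3 carries a different core; how the two cores differ is not broken down here. Its number in this assay is the lowest of the three, beyond the scatter from compound 1 and from compound 2.

Compound 4, `COc1ccc(/C=C2\CCC/C(=C\c3ccc(Cl)cc3)C2=O)cc1OC`, is not yet measured. It stands to compound 3 as compound 2 stands to compound 1: the change is 4-chlorophenyl in place of 3-chlorophenyl on a double-bonded chain carbon bound to a double-bonded ring carbon, with the place given in the same words as before, so it is the same change. For the measured compounds named here, the only guide to its size is the step from compound 1 to compound 2, which was within the scatter. From compound 3 to compound 4 a step of a 1.1-fold higher number from compound 3 to compound 4 (0.03 log units; within the scatter) is therefore expected, resting on a 1.1-fold higher number from compound 1 to compound 2 (0.03 log units; within the scatter) alone; with a single prior example the expectation is weak. For compound 4 the estimated value in this assay is 5300 nM, expected to lie between 2700 nM and 10500 nM.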

Compound 4, half-maximal inhibitory concentration: 4800 nM
Estimate against measurement, compound 4: 1.1-fold (0.04 log units) above; low and high end bracket the measured number.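

Putting 4-chlorophenyl in place of 3-chlorophenyl gave a 1.0-fold lower number from compound 3 to compound 4 (0.01 log units; within the scatter) in this assay, so the two chlorophenyl isomers cannot be told apart on the core of compound 3 either. Set beside the earlier step, the change reads the same on both cores: the same change on two cores in this assay, a 1.1-fold higher number (0.03 log units; within the scatter) from compound 1 to compound 2 and a 1.0-fold lower number (0.01 log units; within the scatter) from compound 3 to compound 4, 1.1-fold (0.04 log units) apart, within the scatter of two such steps

This shows that the swap between these two groups stayed within the scatter on both cores, but it rests on two pairs only and on steps too small to read, so it does not show that a step of readable size would carry from one core to the other, nor that the two isomers would match on any further core.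

All four compounds shown carry a chlorophenyl group at this place, so it remains open whether a different group there, such as an unsubstituted phenyl, a nitrile-bearing phenyl or a phenyl with an amine or a carboxylic acid, would shift the number at all. From the compounds shown here alone, it also remains open whether such a group would act alike on both cores, and whether the match between the isomers holds on cells other than those of this single cytotoxicity read-out.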